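Benzylsulfanyl on the nucleoside core: estimate for compound 4

A few compounds are considered here, and "the series" means these few. Any claim that something is new, unique, unknown or untested is made for them only; others in the source may bear on it.

Measured compounds:
compound 1 `Cc1nsc2[nH]c(SCc3ccccc3)nc12`, 7000 nM
compound 2 `Cc1nsc2c1ncn2[C@H]1C[C@H](O)[C@@H](CO)O1`, > 100000 nM
compound 3 `CSc1nc2c(C)nsc2n1[C@H]1C[C@H](O)[C@@H](CO)O1`, > 100000 nM

In a functional assay on L1210 cells (Mus musculus) for antiproliferative activity (a lower number here means a stronger inhibitor, a higher number a weaker inhibitor), compound 1 gives 7000 nM. For compound 2 the value > 100000 nM is a limit of the assay, not a number. For compound 3 the value > 100000 nM is likewise a limit. Compound 3 thus stands at the limit of > 100000 nM in this assay, at which 2 of the 3 values shown sit. The step that the two limits leave unreadable from compound 2 to compound 3 cannot be read, since both of its ends are limits.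

Compound 4 `Cc1nsc2c1nc(SCc1ccccc1)n2[C@H]1C[C@H](O)[C@@H](CO)O1` differs from compound 3 by phenyl in place of hydrogen on a saturated chain carbon bound to a sulfur. Going by the values given here, no measured step bears directly on this change. Among the compounds with values here, the only related numbers are those of compound 1, which carries the benzylsulfanyl group and gives a finite value, and of compound 3, which carries the methylsulfanyl group and sits at the limit; the two differ in more than one place, so no step between them is readable.

Compound 4 is expected to remain weak, estimated at 100000 nM with a range of 20000 nM to 300000 nM. The step of a number no higher from compound 3 to compound 4 (the limit leaves the size open) is expected to be small, and the assay may again report only a limit.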

Compound 4, half-maximal inhibitory concentration: > 100000 nM
Compound 4 ended at the assay's limit; the forecaster's own chance of this, stated with the estimate: 60%; the middle value lies on the limit itself.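

In this assay, going by these compounds alone, 4-hydroxy-5-(hydroxymethyl)oxolan-2-yl in place of hydrogen on an aromatic nitrogen gives an at least 14-fold higher number from compound 1 to compound 4 (1.15 log units; beyond the scatter), the first readable step, and it shows that benzylsulfanyl alone does not keep the finite value of compound 1 once this group is present. Compound 4 gives > 100000 nM, which is a limit of the assay, so the steps among compound 2, compound 3 and compound 4 cannot be read, and no effect of phenyl on the saturated chain carbon bound to a sulfur can be seen. The limit now dominates the set: the limit of > 100000 nM in this assay, at which 3 of the 4 values shown sit.

On these data alone, whether methylsulfanyl, benzylsulfanyl or hydrogen on the aromatic carbon differ at all stays open. Also open, as far as these compounds go, is whether an amine at that carbon, or a longer chain in place of benzyl, would give a finite value with the oxolanyl group present.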